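The source may hold more compounds than are shown below. What is called first, only, known or untested is meant among the compounds shown, and "the series" means these compounds.

Compound 1 `N#CC1=C(N)Oc2c(N)cc3nc4ccccc4nc3c2C12C(=O)N(Cc1cnnn1-c1ccccc1Cl)c1ccccc12`: 29800 nM
Compound 2 `N#CC1=C(N)Oc2c(N)cc3nc4ccccc4nc3c2C12C(=O)N(Cc1cnnn1-c1ccc([N+](=O)[O-])cc1[N+](=O)[O-])c1ccccc12`: > 50000 nM, which is a limit of the assay rather than a number.
Compound 3 `N#CC1=C(N)Oc2c(N)cc3nc4ccccc4nc3c2C12C(=O)N(Cc1cnnn1-c1c(Cl)cc(Cl)cc1Cl)c1ccccc12`: > 50000 nM, likewise a limit of the assay.

All three were tested in a functional assay on A549 cells (Homo sapiens) for antiproliferative activity, read by MTT assay, with a stated time of 48 h; a lower number here means a stronger inhibitor, a higher number a weaker inhibitor. Compound 1 carries a 2-chlorophenyl on the aromatic nitrogen of its triazole and is the only one of the three with a real number. Compound 3 stands at a limit only, because of the limit of > 50000 nM in this assay, at which 2 of the 3 values shown sit. The two steps away from compound 1 are an at least 1.6-fold higher number from compound 1 to compound 2 (0.22 log units; that floor lies within the scatter) and an at least 1.6-fold higher number from compound 1 to compound 3 (0.22 log units; that floor lies within the scatter), while a step that the two limits leave unreadable from compound 2 to compound 3. So the numbers say only that the 2,4-dinitrophenyl and the 2,4,6-trichlorophenyl compounds are weaker than what the assay can resolve, and nothing about how much.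

Compound 4 `COc1cc(-n2nncc2CN2C(=O)C3(C(C#N)=C(N)Oc4c(N)cc5nc6ccccc6nc5c43)c3ccccc32)c(OC)cc1Cl` differs from compound 3 by 4-chloro-2,5-dimethoxyphenyl in place of 2,4,6-trichlorophenyl on an aromatic nitrogen. Going by the values given here, no measured step involves a group of this kind, so the expectation rests on the shared picture that compound 2 and compound 3 both sit at the limit. Compound 4 is expected to land near that limit too, at an estimated 45000 nM, somewhere between 15000 nM and 120000 nM. That estimate would mean an at least 1.1-fold lower number from compound 3 to compound 4 (0.04 log units; that floor lies within the scatter).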

Compound 4, half-maximal inhibitory concentration: > 50000 nM
Compound 4 was reported as a limit (the forecaster's own chance of this, stated with the estimate: 55%); at least 1.1-fold (0.04 log units) between middle value and limit.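

Compound 4 shows that a phenyl group with hydrogen-bond acceptors, which the 2,4,6-trichlorophenyl lacks, still gives no readable number on this aromatic nitrogen. In this assay, going by these compounds alone, the value of compound 4 is a limit of the assay and not a number: the limit of > 50000 nM in this assay, at which 3 of the 4 values shown sit. The only readable step is an at least 1.6-fold higher number from compound 1 to compound 4 (0.22 log units; that floor lies within the scatter), while the steps among compound 2, compound 3 and compound 4 cannot be read, so compound 1 with its 2-chlorophenyl remains the one exception to the shared limit.

The compounds shown leave open how far past the limit compound 2, compound 3 and compound 4 lie. They also leave open whether an unsubstituted phenyl, a 2-methoxyphenyl or a phenyl bearing an amine at this position would give a readable number.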